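Formyl in Place of Ethyl: Compound 3 to Compound 4

This account rests on a few compounds, and the source may have more. Where it says the series, first, only, none or still open, it means among the compounds named here.

In a functional assay on OVCAR-8 cells (Homo sapiens) for inhibition, read by sulforhodamine B assay, with a stated time of 48 h, tested at 10 uM (a higher number here means more inhibition at the concentration tested (going by the name of the read-out), a lower number less inhibition), compound 1 `c1ccc(-c2cn3ccnc3c(-c3ccc4ncn(C5CCCCC5)c4c3)n2)cc1` gives 63.9%, compound 2 `O=Cc1ccc(-c2cn3ccnc3c(-c3ccc4ncn(C5CCCCC5)c4c3)n2)cc1` gives 44%, and compound 3 `CCc1ccc(-c2cn3ccnc3c(-c3ccc4ncn(Cc5ccccc5)c4c3)n2)cc1` gives 30.8%, the lowest of the three, its gap to compound 2 and to compound 1 lying beyond the scatter. Compound 4 `O=Cc1ccc(-c2cn3ccnc3c(-c3ccc4ncn(Cc5ccccc5)c4c3)n2)cc1` has not yet been measured. The change is formyl in place of ethyl on an aromatic carbon. Among the compounds with values here, only one measured step bears on it: a number 19.9 percentage points lower from compound 1 to compound 2 (beyond the scatter), where a formyl group also enters on an aromatic carbon, though there it replaced hydrogen rather than ethyl. Taking that step as the nearest guide, a modest drop is expected for compound 4, estimated at 20% with a range from 5% to 38%. The expected step is a number 10.8 percentage points lower from compound 3 to compound 4 (beyond the scatter).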

Compound 4, a percentage reported as inhibition, at one concentration (the size of the read-out at that concentration, not a potency): 44%
The estimate for compound 4 lay 24 percentage points below the measured number, outside the stated range (above it).
By their numbers in this assay, from the lowest: compound 3; then compounds 2 and 4 (each within the scatter of the next); then compound 1.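

Formyl in place of ethyl gives a number 13.2 percentage points higher from compound 3 to compound 4 (beyond the scatter) in this assay and so, at this position, formyl does not always go with a lower number, unlike the earlier step with hydrogen as the group replaced, a number 19.9 percentage points lower from compound 1 to compound 2 (beyond the scatter) on the cyclohexyl compounds. With formyl in place, benzyl in place of cyclohexyl on the aromatic nitrogen gives no change at the digits printed from compound 2 to compound 4 (within the scatter) and so makes no visible difference between these two compounds.

From the compounds shown here alone, how an amine or a carboxylic acid on this aromatic carbon would read remains open. Why the numbers move this way also remains open, as no evidence bears on it.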